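This account rests on a few compounds, and the source may have more. Where it says the series, first, only, none or still open, it means among the compounds named here.

The three measured compounds:
Compound 1 `COc1ccc(CNc2nc([Se]C)nc3ccccc23)cc1` gives > 100000 nM in a functional assay on CCRF-CEM cells (Homo sapiens) for cytotoxicity, read by MTT assay, with a stated time of 72 h (on this read-out lower numbers stand for stronger inhibition of growth and higher numbers for weaker inhibition of growth), which is a limit of the assay.
Compound 2 `CSc1nc(NCCCCCO)c2cccnc2n1` gives > 100000 nM in this assay, again a limit.
Compound 3 `C[Se]c1nc(NCc2ccccc2)c2ccccc2n1` gives 39800 nM in this assay.

Compound 1 thus stands at the limit of > 100000 nM in this assay, at which 2 of the 3 values shown sit, with no exact number known. Among the measured compounds shown here, the only measured step, an at least 2.5-fold lower number from compound 1 to compound 3 (0.40 log units; beyond the scatter), concerns the methoxy group and not the part changed here. Compound 4 `COc1ccc(CNc2nc(SC)nc3ccccc23)cc1` differs from compound 1 by a group of 2 heavy atoms (1 carbon, 1 sulfur; no ring) in place of a group of 2 heavy atoms (1 carbon, 1 selenium; no ring), on an aromatic carbon. For the measured compounds named here, no measured step covers this exchange; compound 2, which also carries methylsulfanyl, sits at a limit too. Compound 4 is therefore expected to show a number no higher from compound 1 to compound 4 (the limit leaves the size open), no shift beyond the scatter. The estimate for compound 4 is 100000 nM, within a range from 30000 nM to 300000 nM, most likely reported only as a limit.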

Compound 4, concentration for 50% growth inhibition: 93700 nM
For compound 4 the middle estimate is 1.1-fold (0.03 log units) above the measured one; the measured number falls inside the stated range.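

Exchanging the selenium-bearing group for methylsulfanyl on this aromatic carbon, between two ring nitrogen atoms, gives an at least 1.0-fold lower number from compound 1 to compound 4 (0.02 log units; that floor lies within the scatter). So the exchange shows no shift that can be told from the scatter, and growth inhibition stays weak. The true size of the step stays unknown because compound 1 has only a limit: the limit of > 100000 nM in this assay, at which 2 of the 4 values shown sit.

The compounds shown leave open whether an amine or a longer chain on the sulfur at this position would change the number. They also leave open whether methylsulfanyl would behave the same way with hydrogen in place of methoxy.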